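The compounds below may be only part of what the source reports. "The series", "measured", "known", "first", "only" and "open" are said of these compounds alone.

Series values in a functional assay on MDA-MB-231 cells (Homo sapiens) for cytotoxicity, read by MTT assay; on this read-out higher numbers stand for weaker inhibition and lower numbers for stronger inhibition:
- compound 1 `CCCOc1c(Br)cc(/C=C2\CCC/C(=C\c3cccc([N+](=O)[O-])c3)C2=O)cc1OC`: 2.99 ug/mL
- compound 2 `COc1cc(/C=C2\CCC/C(=C\c3ccc([N+](=O)[O-])cc3)C2=O)cc(Br)c1O`: > 100 ug/mL
- compound 3 `COc1cc(/C=C2\CCC/C(=C\c3ccc([N+](=O)[O-])cc3)C2=O)cc(Br)c1OC`: 8.71 ug/mL

Compound 3 holds the higher of the two true numbers at 8.71 ug/mL. Compound 1 lies lower at 2.99 ug/mL, a gap beyond the scatter. Compound 2 gives > 100 ug/mL, which is a limit of the assay and not a number.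

Next is compound 4 `CCCOc1c(Br)cc(/C=C2\CCC/C(=C\c3ccc([N+](=O)[O-])cc3)C2=O)cc1OC`, which differs from compound 3 by ethyl in place of hydrogen on a saturated chain carbon bound to an oxygen on an aromatic ring, that is, methoxy to propoxy. Among the measured compounds shown here, the one measured step on this oxygen is an at least 11-fold lower number from compound 2 to compound 3 (1.05 log units; beyond the scatter). It is large, but its size is only a bound, set by the limit of > 100 ug/mL in this assay, at which 1 of the 3 values shown sits, and it is a different change, so its size is not carried over. Compound 1 carries the same propoxy group as compound 4 and differs from it only in the placing of the nitro group. The value of compound 1 at 2.99 ug/mL gives a modest lean towards a lower number. The estimated move is a 1.7-fold lower number from compound 3 to compound 4 (0.24 log units; within the scatter), and it is not expected to pass the scatter in this assay. For compound 4 the expected value is 5 ug/mL, with an estimated range of 1.5 ug/mL to 20 ug/mL.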

Compound 4, half-maximal inhibitory concentration: 4.01 ug/mL
The estimate for compound 4 lay 1.2-fold (0.10 log units) above the measured number; measured number inside the range.
By their numbers in this assay, from the lowest: compounds 1 and 4 (each within the scatter of the next); then compound 3. At a limit, above all of these: compound 2.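

In this assay, among the compounds shown here, methoxy to propoxy gives a 2.2-fold lower number from compound 3 to compound 4 (0.34 log units; beyond the scatter), the first reading of chain length on this oxygen, since the earlier step covered only hydrogen to methyl; the change from methyl to propyl still moves the number beyond the scatter, though modestly. Propyl in place of the hydrogen on this oxygen gives an at least 24-fold lower number from compound 2 to compound 4 (1.39 log units; beyond the scatter), but that size is only a bound, since compound 2 stands at a limit and not at a number: the limit of > 100 ug/mL in this assay, at which 1 of the 4 values shown sits. With propoxy in place, 4-nitrophenyl in place of 3-nitrophenyl gives a 1.3-fold higher number from compound 1 to compound 4 (0.13 log units; within the scatter), so the two placings of the nitro group cannot be told apart in this assay.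

Only hydrogen, methyl and propyl are shown on this oxygen, so it remains open whether a longer chain such as hexyl would shift the number further, or whether a chain ending in an amine or a carboxylic acid would keep the effect. For the compounds shown here, the comparison of the nitro placings also rests on the single pair with propoxy, and how it reads with methoxy on this oxygen stays open.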